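A few compounds are considered here, and "the series" means these few. Any claim that something is new, unique, unknown or untested is made for them only; others in the source may bear on it.

Working notes on a small series built on a shared core, followed in a physicochemical assay for lipophilicity, using the shake flask method, at pH 7.4 (on this read-out lower numbers stand for lower lipophilicity and higher numbers for higher lipophilicity), here. In this assay compound 1 `CC(C)(Oc1ccccc1)C(=O)Nc1ccc(OCC(=O)O)c(F)c1` stands at "not determined" (no result reported) with no number behind that entry. In the same read-out compound 2 `CCOc1ccccc1OC(C)C(=O)Nc1ccc(OCC(=O)O)c(F)c1` also stands at "not determined" (no result reported) and offers no number either. For the measured compounds named here, compound 3 `CC(Oc1ccccc1F)C(=O)Nc1ccc(OCC(=O)O)c(F)c1` gives 0.07 and so holds the only number in the set, which leaves it without a measured neighbour to be ranked against.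

The next entry is compound 4 `Cc1ccc(OC(C)C(=O)Nc2ccc(OCC(=O)O)c(F)c2)cc1C`, still unmeasured in this assay at this point. The change is 3,4-dimethylphenyl in place of 2-fluorophenyl on an oxygen on a saturated carbon and reads as 3,4-dimethylphenyl in place of 2-fluorophenyl on an oxygen on a saturated carbon, with the rest of the structure untouched. Going by the values given here, no step between measured compounds exists, so the expectation rests on the structural change alone and has no measured precedent. A move upward is expected, of a size beyond the usual scatter. The estimated step of a number 0.73 log units higher from compound 3 to compound 4 (beyond the scatter) is therefore expected to show clearly in this assay once a number arrives. For compound 4 the estimated value is 0.8 with an expected range from 0.4 to 1.2 around it.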

Compound 4, distribution coefficient: 0.33
Compound 4: the middle estimate sits 0.47 log units above what was measured; measured number outside the range, below it.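

In this assay, for the compounds shown here, 3,4-dimethylphenyl in place of 2-fluorophenyl on an oxygen on a saturated carbon gives a number 0.26 log units higher from compound 3 to compound 4 (within the scatter), the first step that can be read. At this position, then, the read-out does not separate compound 3 and compound 4, even though the exchange removes the only fluorine of the leaving group, brings in 8 heavy atoms, all carbon, for 7, and leaves the single six-membered aromatic ring, the zero counts of hydrogen-bond donors and acceptors, and the absence of net charge as they were. No independent measurement bears on why the two compounds sit within the scatter of each other.

Steps that reach compound 1 or compound 2 cannot be read, so this single pair remains the whole measured basis for the position and supports no wider pattern. Still open, as far as these compounds go, is how the read-out responds when the group on this oxygen carries an amine or a carboxylic acid, or when a longer chain takes the place of the aromatic ring.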